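This account rests on a few compounds, and the source may have more. Where it says the series, first, only, none or still open, it means among the compounds named here.

Measured compounds:
compound 1 `C[C@@H](O)[C@H](NC(=O)CN(c1nc(Cl)nc2[nH]cnc12)C1CC1)C(=O)O` gives 30.1% in a functional assay on the whole organism (Tail, strain ICR) with Mus musculus as the target, in the tail flick test, with a stated time of 60 min, at a dose of 25 umol/kg by the oral route; a lower number here means a weaker effect, a higher number a stronger effect of the compound at the dose given
compound 2 `CC(C)[C@H](NC(=O)CN(c1nc(Cl)nc2[nH]cnc12)C1CC1)C(=O)OCc1ccccc1` gives 55.5% in this assay
compound 3 `NC(=O)C[C@H](NC(=O)CN(c1nc(Cl)nc2[nH]cnc12)C1CC1)C(=O)OCc1ccccc1` gives 36.4% in this assay

Compound 1 stands lowest of these three numbers. Its nearest neighbour is compound 3, whose value lies within the scatter of compound 1, so the two cannot be told apart; compound 2 lies beyond the scatter above compound 1.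

Compound 4 `CC(C)C[C@H](NC(=O)CN(c1nc(Cl)nc2[nH]cnc12)C1CC1)C(=O)O` differs from compound 1 in one place: isobutyl in place of 1-hydroxyethyl on a saturated chain carbon bound to an amide-type nitrogen and a carbonyl carbon. Isobutyl brings no hydrogen-bond donor or acceptor, where 1-hydroxyethyl carried one of each.

Within the data shown here, one measured step bears on this position, the side group on the saturated chain carbon bound to an amide-type nitrogen and a carbonyl carbon: a number 19.1 percentage points lower from compound 2 to compound 3 (beyond the scatter), where carbamoylmethyl replaced isopropyl. Among the measured compounds shown here, the change from compound 1 to compound 4 runs the other way, towards a plain hydrocarbon side group, so a modest rise is expected rather than a fall, with wide uncertainty since only one step is known.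

Compound 4 is therefore expected to give 45% in this assay, between 30% and 62%. This estimate means an expected step of a number 14.9 percentage points higher from compound 1 to compound 4 (beyond the scatter).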

Compound 4, a percentage reported as activity, at one dose (the size of the read-out at that dose, not a potency): 36.4%
For compound 4 the middle estimate is 8.6 percentage points above the measured one; low and high end bracket the measured number.
By their numbers in this assay, from the lowest: compounds 1, 3 and 4 (each within the scatter of the next); then compound 2.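

Exchanging 1-hydroxyethyl for isobutyl on a saturated chain carbon bound to an amide-type nitrogen and a carbonyl carbon gives a number 6.3 percentage points higher from compound 1 to compound 4 (within the scatter) in this assay and so produces no readable change. Among these compounds, in this pair, both of which end in a free carboxylic acid, the side group can therefore lose its hydrogen-bond donor and acceptor and become all carbon without a measurable shift, whereas the only earlier step at this position, a number 19.1 percentage points lower from compound 2 to compound 3 (beyond the scatter), lay beyond the scatter and involved different side groups on compounds carrying a benzyl ester. Nothing measured here explains why one step registers and the other does not.

On these data alone, it remains open whether a side group ending in an amine, or a longer hydrocarbon chain, would move the number at this position in the free acids. Also open, as far as these compounds go, is whether isobutyl and 1-hydroxyethyl would still be indistinguishable in this test if each were carried on a benzyl ester, which would separate the effect of the side group from that of the ester.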